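The source may report more compounds than this note shows. Statements on the series, on what has been measured and on what is new or still open speak of the compounds shown alone.

Compound 1 `Cc1n[nH]c(C)c1Oc1c(O)cc(O)c2c(=O)cc(-c3ccc(N4CCCNCC4)cc3)oc12`: 17600 nM
Compound 2 `Cc1n[nH]c(C)c1Oc1c(O)cc(O)c2c(=O)cc(-c3ccc(N4CCN(C(C)C)CC4)cc3)oc12`: 16300 nM
Compound 3 `COc1c(O)cc(O)c2c(=O)cc(-c3ccc(N4CCCNCC4)cc3)oc12`: 31600 nM

The three compounds were tested in an assay on cells for inhibition of ubiquitin carboxyl-terminal hydrolase 8 (Homo sapiens), read by fluorescence, with a stated time of 30 min; on this read-out higher numbers stand for weaker inhibition and lower numbers for stronger inhibition. Compound 3 gives the highest number of the three, but the step of a 1.8-fold higher number from compound 1 to compound 3 (0.25 log units; within the scatter) lies within the scatter, and so does the gap between compound 3 and compound 2, so nothing can be said about an order among them.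

Compound 4 `COc1c(O)cc(O)c2c(=O)cc(-c3ccc(N4CCCC4)cc3)oc12` has not yet been measured. It differs from compound 3 in one place: pyrrolidin-1-yl in place of 1,4-diazepan-1-yl on an aromatic carbon. The step that bears most on this change is the one in which another amine ring on the same aromatic carbon was exchanged, a 1.1-fold lower number from compound 1 to compound 2 (0.03 log units; within the scatter), which produced no change beyond the scatter. The other step, a 1.8-fold higher number from compound 1 to compound 3 (0.25 log units; within the scatter), concerns a different position and also stayed within the scatter. Among the measured compounds shown here, with only one related exchange to go on, a step of a 1.1-fold higher number from compound 3 to compound 4 (0.04 log units; within the scatter) is expected, that is, none beyond the scatter. Compound 4 is therefore estimated at 35000 nM, with a range from 12000 nM to 100000 nM.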

Compound 4, half-maximal inhibitory concentration: 16200 nM
Compound 4: middle estimate off by 2.2-fold (0.33 log units), on the high side; low and high end bracket the measured number.
By their numbers in this assay, from the lowest: compounds 4, 2, 1 and 3 (each within the scatter of the next).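

In this assay, putting pyrrolidin-1-yl in place of 1,4-diazepan-1-yl on the aromatic carbon gives a 2.0-fold lower number from compound 3 to compound 4 (0.29 log units; within the scatter). The earlier exchange at this position kept a ring with two nitrogens, whereas this one moves to a five-membered ring with a single hetero atom and no hydrogen-bond donor, and the number still stays within the scatter, so the position has so far tolerated both kinds of ring in this assay. No measurement available here explains this result or shows how these rings act on the enzyme.

Still open, from the compounds shown here alone, is whether a morpholin-4-yl ring, a carboxylic acid or a longer amine chain at this place would move the number beyond the scatter. Also open, going by these compounds, is how pyrrolidin-1-yl behaves alongside the 3,5-dimethyl-1H-pyrazol-4-yl group on the oxygen of the shared core.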